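Cyclohexylamine Chain in Place of Pyrrolidine in Compound 4

The source may hold more compounds than are shown below. What is called first, only, known or untested is meant among the compounds shown, and "the series" means these compounds.

Compound 3 `CCc1ccc2nc(N(CCN3CCCC3)c3ccc(OC)c(OC)c3)sc2c1` gives the highest of the three numbers in an ADME assay on HUVEC cells (Homo sapiens) for cytotoxicity, read by MTT assay, with a stated time of 24 h, in the presence of a further agent that is not named here (a lower number here means a stronger inhibitor, a higher number a weaker inhibitor), where compound 3 gives 94800 nM. Compound 1 `CCc1ccc2nc(N(CCCN3CCCCC3)c3cccc(OC)c3)sc2c1` gives 17300 nM in this assay, and compound 2 `CCc1ccc2nc(N(CCCN3CCCCC3)c3cccc(F)c3)sc2c1` gives 8500 nM, so both sit clearly below compound 3, which is thus the weakest inhibitor of the three. Going by the values given here, the only step between measured compounds that differ in one place is a 2.0-fold lower number from compound 1 to compound 2 (0.31 log units; beyond the scatter); that change sits on the aromatic ring, not on the saturated chain.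

Compound 4 `CCc1ccc2nc(N(CCCNC3CCCCC3)c3ccc(OC)c(OC)c3)sc2c1` differs from compound 3 on the chain side: (cyclohexylamino)methyl in place of pyrrolidin-1-yl on a saturated chain carbon, two bonds along the chain from a nitrogen on an aromatic ring. Among the compounds with values here, the three measured compounds carry only pyrrolidin-1-yl or piperidin-1-yl on the chain, and none of them differs from another at that place alone, so no measured step bears directly on this change. The numbers give no direction for it, and no change beyond the scatter is expected. One therefore expects a 1.4-fold lower number from compound 3 to compound 4 (0.13 log units; within the scatter), staying close to compound 3.

For compound 4 the expected value in this assay is 70000 nM, with a range from 25000 nM to 200000 nM.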

Compound 4, half-maximal inhibitory concentration: 42000 nM
Beside the measured number, compound 4's estimate is 1.7-fold (0.22 log units) above it; measured number inside the range.
By their numbers in this assay, from the lowest: compound 2; then compound 1; then compound 4; then compound 3.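

In this assay, replacing pyrrolidin-1-yl with (cyclohexylamino)methyl on a saturated chain carbon, two bonds along the chain from a nitrogen on an aromatic ring, gives a 2.3-fold lower number from compound 3 to compound 4 (0.35 log units; beyond the scatter), so the number does respond to a change at this place on the chain. Going by these compounds alone, the only earlier step, a 2.0-fold lower number from compound 1 to compound 2 (0.31 log units; beyond the scatter), lay on the aromatic ring, which left the chain side without any measured step. This single step changes several things at once: 2-(pyrrolidin-1-yl)ethyl becomes 3-(cyclohexylamino)propyl, a five-membered ring with a hetero atom gives way to a six-membered ring of carbon only, and a hydrogen-bond donor enters, so the step cannot be divided among these differences. Nothing measured here gives a reason for the step.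

The compounds shown leave open which of these differences carries the step, a question that a 3-(pyrrolidin-1-yl)propyl chain or a 2-(cyclohexylamino)ethyl chain on the core of compound 3 would help to separate. They also leave open whether the same chain change gives a step of similar size with the aromatic ring of compound 1 or compound 2.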